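Moving the Hydroxyl Group on the Pendant Phenyl Ring

The source may hold more compounds than are shown below. What is called first, only, known or untested is meant among the compounds shown, and "the series" means these compounds.

Compound 2 `Cc1ccccc1N(C)C(=O)c1ccc(-c2ccccc2O)o1` is the weakest of three compounds in an assay on T47D cells for inhibition of 17-beta-hydroxysteroid dehydrogenase type 1 (Homo sapiens), read by HPLC, with a stated time of 24 h (on this read-out lower numbers stand for stronger inhibition and higher numbers for weaker inhibition), where compound 2 gives 1900 nM. Compound 1 `Cc1ccccc1N(C)C(=O)c1ccc(-c2cccc(O)c2)o1` gives 29 nM and compound 3 `Cc1cc(-c2ccc(C(=O)N(C)c3ccccc3C)o2)ccc1O` gives 8.6 nM. All three steps between them lie beyond the scatter: a 66-fold higher number from compound 1 to compound 2 (1.82 log units; beyond the scatter), a 3.4-fold lower number from compound 1 to compound 3 (0.53 log units; beyond the scatter) and a 220-fold lower number from compound 2 to compound 3 (2.34 log units; beyond the scatter). Compound 4 `Cc1ccccc1N(C)C(=O)c1ccc(-c2ccc(O)cc2F)o1` differs from compound 2 in a single place: 2-fluoro-4-hydroxyphenyl in place of 2-hydroxyphenyl on an aromatic carbon. The measured step that bears most on this change is the one in which the 2-hydroxyphenyl group was likewise exchanged for a group with the hydroxyl in the 4-position, and that step was large: a 220-fold lower number from compound 2 to compound 3 (2.34 log units; beyond the scatter). For the measured compounds named here, compound 3 and compound 4 share the 4-hydroxy arrangement but differ in the second substituent, methyl against fluorine, and no measured step tells how much that matters. The expected step is therefore large and downward, a 130-fold lower number from compound 2 to compound 4 (2.10 log units; beyond the scatter). Compound 4 is estimated at 15 nM, with a likely range from 4 nM to 60 nM.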

Compound 4, half-maximal inhibitory concentration: 10 nM
The estimate for compound 4 lay 1.5-fold (0.18 log units) above the measured number; the range from low to high includes it.
By their numbers in this assay, from the lowest: compounds 3 and 4 (each within the scatter of the next); then compound 1; then compound 2.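

In this assay, the large gain over the 2-hydroxyphenyl group does not depend on the methyl of compound 3, since the 2-fluoro-4-hydroxyphenyl group gives (a 190-fold lower number from compound 2 to compound 4 (2.28 log units; beyond the scatter)) with fluorine as the second substituent. Methyl and fluorine could not be told apart in these two groups, as the exchange gives (a 1.2-fold higher number from compound 3 to compound 4 (0.07 log units; within the scatter)), so the choice between them makes no measurable difference here. Compound 4 also improves on the 3-hydroxyphenyl group (a 2.9-fold lower number from compound 1 to compound 4 (0.46 log units; beyond the scatter)), so both groups with the hydroxyl in the 4-position give lower numbers than compound 1. No measurement available here explains these differences. As far as these compounds go, it also remains open whether a plain 4-hydroxyphenyl group, with no second substituent, would keep the low number, or whether a 4-methoxyphenyl or 4-aminophenyl group could replace it.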